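The compounds below may be only part of what the source reports. "The series", "measured", "known", "first", "only" and "open" are said of these compounds alone.

Three compounds have already been run in a physicochemical assay, with a stated time of 60 min; a higher number here means a weaker inhibitor, a lower number a stronger inhibitor. Compound 1 `CCOC(=O)[C@@H]1C(=O)N(Cc2ccccc2)C[C@@H](ON2C(C)(C)CCCC2(C)C)[C@H]1c1ccccc1` gives 12300 nM in this assay. Compound 3 `CCOC(=O)[C@@H]1C(=O)N(Cc2ccccc2)C[C@@H](ON2C(C)(C)CCCC2(C)C)[C@H]1c1ccc(F)cc1` carries one change relative to compound 1, namely (fluoro in place of hydrogen on an aromatic carbon), and in this assay compound 3 gives 15900 nM. The step of a 1.3-fold higher number from compound 1 to compound 3 (0.11 log units; within the scatter) shows the change left the number essentially where it was.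

Compound 2 `CC1(C)CCCC(C)(C)N1O[C@@H]1CN(Cc2ccccc2)C[C@@H](CO)[C@@H]1c1ccccc1` is built on a different core; the difference between the two cores is not broken down here. In this assay compound 2 gives 93 nM, the lowest number of the three and a much stronger inhibitor than either compound 1 or compound 3.

Compound 4 `CC1(C)CCCC(C)(C)N1O[C@@H]1CN(Cc2ccccc2)C[C@@H](CO)[C@@H]1c1ccc(F)cc1` has not yet been measured. It stands to compound 2 exactly as compound 3 stands to compound 1: the change is fluoro in place of hydrogen on an aromatic carbon, at the same place, para to a large group, on the same kind of ring. Because the matching step a 1.3-fold higher number from compound 1 to compound 3 (0.11 log units; within the scatter) was small, the step from compound 2 to compound 4 is expected to be small as well, roughly a 1.2-fold higher number from compound 2 to compound 4 (0.09 log units; within the scatter). The expectation rests on a single earlier example, so it is held loosely. Compound 4 is therefore estimated to give about 115 nM in this assay, most likely somewhere between 45 nM and 300 nM.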

Compound 4, half-maximal inhibitory concentration: 95 nM
Compound 4: middle estimate off by 1.2-fold (0.08 log units), on the high side; low and high end bracket the measured number.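

In this assay the new pair shows a 1.0-fold higher number from compound 2 to compound 4 (0.01 log units; within the scatter) and the earlier pair shows a 1.3-fold higher number from compound 1 to compound 3 (0.11 log units; within the scatter) on the other core, so phenyl to 4-fluorophenyl left the number essentially where it was on both cores. Within the data shown here, this is a narrow result: it rests on only two pairs, and a change that does almost nothing on either core is a weak test of transfer, since it does not show that a change with a large effect would carry across in the same way, or that this one would behave alike on a third core or in a different assay. No measurement shown here explains why the fluoro made so little difference.

The compounds shown vary the phenyl ring only by this single swap at this single place, so it remains open whether a chloro, methoxy or trifluoromethyl group there would also pass between the two cores with so little effect. From the compounds shown here alone, it also remains open whether a group such as an amine or a carboxylic acid on that ring would move the number, and whether any such step would match from one core to the other.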